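Aromatic methyl step on two cores in the agonist series

A few compounds are considered here, and "the series" means these few. Any claim that something is new, unique, unknown or untested is made for them only; others in the source may bear on it.

Compound 1 `CC(C#CCn1ccnc1)N1CCCC1=O` and compound 2 `Cc1cncn1CC#CC(C)N1CCCC1=O` differ by methyl in place of hydrogen on an aromatic carbon. In a functional assay on the whole organism for agonist activity, with Mus musculus as the target (on this read-out lower numbers stand for an effect already at smaller amounts and higher numbers for an effect only at larger amounts of compound), compound 1 reaches only the limit of > 100 mg/kg. Compound 2 likewise reaches only a limit in this assay, namely > 100 mg/kg. The step that the two limits leave unreadable from compound 1 to compound 2 therefore has no readable size. Compound 3 `CC1CCC(=O)N1CC#CCn1ccnc1` has the same atoms as compound 1, joined differently; the difference between the two cores is not broken down here. In this assay compound 3 also gives only a limit, > 100 mg/kg. Compound 4 `Cc1cncn1CC#CCN1C(=O)CCC1C`, not yet measured, differs from compound 3 by methyl in place of hydrogen on an aromatic carbon, the same change as that from compound 1 to compound 2, at the same place. Given (the limit of > 100 mg/kg in this assay, at which 3 of the 3 values shown sit), the step that the limit leaves unreadable from compound 3 to compound 4 is expected to stay within the limits rather than to show a readable size. Compound 4 is estimated at 150 mg/kg, most likely reported again as a limit.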

Compound 4, dose for half-maximal effect: > 100 mg/kg
Compound 4: a limit, no number (the forecaster's own chance of this, stated with the estimate: 85%); the middle value is on the limit's open side.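

In this assay compound 4 gives only a limit, > 100 mg/kg. The step between compound 3 and compound 4 therefore cannot be read. The compounds shown leave open whether methyl in place of hydrogen on an aromatic carbon changes the half-maximal dose on either core.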